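Ethylamino to thiazolylamino in the cytotoxic series

This account rests on a few compounds, and the source may have more. Where it says the series, first, only, none or still open, it means among the compounds named here.

Values in a functional assay on KB cells (Homo sapiens) for cytotoxicity, read by MTT assay, with a stated time of 3 days; a higher number here means a weaker inhibitor, a lower number a stronger inhibitor:
- compound 1 `N#Cc1c(Cl)nc(SCc2nc3ccccc3[nH]2)nc1-c1ccccc1`: 3.7 nM
- compound 2 `CCNc1nc(SCc2nc3ccccc3[nH]2)nc(-c2ccccc2)c1C#N`: 7.35 nM

For the measured compounds named here, compound 2, at 7.35 nM, stands within the scatter of the only other measured compound. Compound 3 `N#Cc1c(Nc2nccs2)nc(SCc2nc3ccccc3[nH]2)nc1-c1ccccc1` is the next case: 1,3-thiazol-2-yl in place of ethyl on a nitrogen on an aromatic ring. Here 1,3-thiazol-2-yl stands in place of ethyl on a nitrogen on an aromatic ring. Going by the values given here, one measured step bears on this, a 2.0-fold higher number from compound 1 to compound 2 (0.30 log units; within the scatter). It concerns the same substituent but not this group, so the basis is thin. No step beyond the scatter is expected in this assay. The estimated step is a 1.4-fold higher number from compound 2 to compound 3 (0.13 log units; within the scatter). For compound 3 the estimate is 10 nM, with an expected range of 2 nM to 40 nM.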

Compound 3, half-maximal inhibitory concentration: 14.7 nM
Compound 3: middle estimate off by 1.5-fold (0.17 log units), on the low side; low and high end bracket the measured number.
By their numbers in this assay, from the lowest: compounds 1, 2 and 3 (each within the scatter of the next, the first and the last beyond it).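

In this assay the change on the nitrogen gives a 2.0-fold higher number from compound 2 to compound 3 (0.30 log units; within the scatter) and so shows that a five-membered aromatic ring can replace ethyl there with no step beyond the scatter. For the compounds shown here, replacing chloro gives a 4.0-fold higher number from compound 1 to compound 3 (0.60 log units; beyond the scatter) as the first step in this set beyond the scatter, though only a modest one. No evidence at hand accounts for either step. Still open, from the compounds shown here alone, is whether morpholine or phenylamino on the same aromatic carbon would stay within the scatter of compound 2 or compound 3.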